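Fluorine on the terminal phenyl of a urea

A few compounds are considered here, and "the series" means these few. Any claim that something is new, unique, unknown or untested is made for them only; others in the source may bear on it.

Three compounds share one core and differ in the group hung from it. In a functional assay on HT-29 cells (Homo sapiens) for cytotoxicity, read by MTT assay, with a stated time of 72 h (a lower number here means a stronger inhibitor, a higher number a weaker inhibitor), compound 1 `COc1cc2c(Oc3ccc(NC(=O)N/N=C/c4ccncc4)cc3F)ccnc2cc1OCCCN1CCCCC1` gives 940 nM, compound 2 `COc1cc2c(Oc3ccc(NC(=S)N/N=C/c4ccccc4)cc3F)ccnc2cc1OCCCN1CCCCC1` gives 210 nM, and compound 3 `COc1cc2c(Oc3ccc(/C=N/NC(=O)Nc4ccccc4)cc3F)ccnc2cc1OCCCN1CCCCC1` gives 190 nM. The steps of a 4.5-fold lower number from compound 1 to compound 2 (0.65 log units; beyond the scatter) and a 4.9-fold lower number from compound 1 to compound 3 (0.69 log units; beyond the scatter) are both beyond the scatter, while the step of a 1.1-fold lower number from compound 2 to compound 3 (0.04 log units; within the scatter) is within it, so compound 3 and compound 2 cannot be told apart on these numbers.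

Compound 4 `COc1cc2c(Oc3ccc(/C=N/NC(=O)Nc4ccc(F)c(F)c4)cc3F)ccnc2cc1OCCCN1CCCCC1` differs from compound 3 by 3,4-difluorophenyl in place of phenyl on an amide-type nitrogen. Within the data shown here, none of the measured steps touches this change: the steps from compound 1 swap the ring kind and the linker, and the step from compound 2 to compound 3 swaps sulfur for oxygen in the linker. Nothing here speaks for a shift beyond the scatter in either direction, and the expected step of a 1.2-fold lower number from compound 3 to compound 4 (0.07 log units; within the scatter) is therefore small. In this assay compound 4 is estimated at 160 nM, with a range from 60 nM to 450 nM.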

Compound 4, half-maximal inhibitory concentration: 490 nM
The estimate for compound 4 lay 3.1-fold (0.49 log units) below the measured number; the whole stated range lies below it.
By their numbers in this assay, from the lowest: compounds 3 and 2 (each within the scatter of the next); then compounds 4 and 1 (each within the scatter of the next).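

The terminal ring on the amide-type nitrogen is not a silent position: in this assay, 3,4-difluorophenyl in place of phenyl gives a 2.6-fold higher number from compound 3 to compound 4 (0.41 log units; beyond the scatter) and so moves the number beyond the scatter. Among the compounds shown, this is the only step confined to this ring, and it shows that adding these two fluorines on the urea's terminal ring makes the compound a weaker inhibitor, not a stronger one. Nothing measured here explains this loss.

As far as these compounds go, it remains open whether the loss needs both fluorines or follows from one of them alone. From the compounds shown here alone, it is also open how a chlorine, a methoxy group or a dimethylamino group on this phenyl would read in this assay on the same core.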